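The source may report more compounds than this note shows. Statements on the series, on what has been measured and on what is new or still open speak of the compounds shown alone.

Measured compounds:
compound 1 `FC(F)(F)c1cccc(Nc2ncnc3sc(Nc4c(Cl)cccc4Cl)nc23)c1`: 192 nM
compound 2 `Clc1cccc(Cl)c1Nc1nc2c(Nc3ccccc3)ncnc2s1`: 170 nM

In a functional assay on HEK293 cells for antagonist activity at transient receptor potential cation channel subfamily V member 1 (Rattus norvegicus), read by calcium flux (on this read-out higher numbers stand for weaker inhibition and lower numbers for stronger inhibition), compound 2 gives 170 nM, the lowest of the two numbers, with compound 1 at 192 nM within the scatter of it. Compound 3 `O=C(c1ccc(Nc2ncnc3sc(Nc4c(Cl)cccc4Cl)nc23)cc1)N1CCCC1` differs from compound 2 by (pyrrolidin-1-yl)carbonyl in place of hydrogen on an aromatic carbon. Among the measured compounds shown here, the only measured step, a 1.1-fold lower number from compound 1 to compound 2 (0.05 log units; within the scatter), concerns a different group on that ring and gives no guide to this change. The step to compound 3 is therefore expected to be a 1.5-fold higher number from compound 2 to compound 3 (0.17 log units; within the scatter) in this assay, with wide uncertainty. Compound 3 is estimated at 250 nM, between 60 nM and 1000 nM.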

Compound 3, half-maximal inhibitory concentration: > 5000 nM
Compound 3: only a limit was reported (the forecaster's own chance of this, stated with the estimate: 10%); at least 20-fold (1.30 log units) between middle value and limit.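

In this assay, compound 3 gives > 5000 nM, which is a limit and not a number. Putting (pyrrolidin-1-yl)carbonyl on the aromatic carbon para to a large group brings an at least 29-fold higher number from compound 2 to compound 3 (1.46 log units; beyond the scatter), so this ring is not indifferent to every change, although the earlier step on it stayed within the scatter. As far as these compounds go, the true size of this step stays unknown: the limit of > 5000 nM in this assay, at which 1 of the 3 values shown sits. The compounds shown leave open whether the carbonyl or the pyrrolidine ring goes with the loss. They also leave open how a primary amide, a carboxylic acid or an amine would behave on this carbon.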